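The source may hold more compounds than are shown below. What is called first, only, known or untested is meant among the compounds shown, and "the series" means these compounds.

Going by the values given here, compound 3 `COc1ccccc1N1CCN(CCCNC(=O)c2cc3ccc(Br)cc3[nH]2)CC1` is one of three compounds measured in an assay on isolated protein (thoracic aorta, strain Sprague-Dawley) for antagonist activity at Alpha-1D adrenergic receptor (Rattus norvegicus), with a stated time of 20 min; a lower number here means tighter binding, a higher number weaker binding. In this assay compound 3 gives 15.1 nM. Compound 1 `COc1ccccc1N1CCN(CCCNC(=O)c2ccc3[nH]ccc3c2)CC1` gives 11.8 nM in this assay, and compound 2 `COc1ccc2[nH]c(C(=O)NCCCN3CCN(c4ccccc4OC)CC3)cc2c1` gives 58.9 nM. Compound 3 therefore stands second highest of the three numbers: its nearest neighbour is compound 1, within the usual scatter of repeated measurements, and its furthest is compound 2, beyond that scatter. Compound 4 `COc1ccccc1N1CCN(CCCNC(=O)c2cc3cc(Cl)ccc3[nH]2)CC1` has not yet been measured. It differs from compound 3 in one place: 5-chloro-1H-indol-2-yl in place of 6-bromo-1H-indol-2-yl on a carbonyl carbon. Among the compounds with values here, only one measured step touches this part of the molecule, a 1.3-fold higher number from compound 1 to compound 3 (0.11 log units; within the scatter), in which the 6-bromo-1H-indol-2-yl group entered and the number moved only within the scatter. Within the data shown here, no measured pair compares a chlorine with a bromine on this ring, and none compares the two halogen positions. The expected step is therefore a 1.1-fold higher number from compound 3 to compound 4 (0.03 log units; within the scatter), nothing beyond the scatter. Compound 4 is estimated at 16 nM, with a likely range from 6 nM to 45 nM.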

Compound 4, dissociation constant: 19.5 nM
For compound 4 the middle estimate is 1.2-fold (0.09 log units) below the measured one, and the stated range covers the measured number.
By their numbers in this assay, from the lowest: compounds 1, 3 and 4 (each within the scatter of the next); then compound 2.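

In this assay, replacing 6-bromo-1H-indol-2-yl with 5-chloro-1H-indol-2-yl gives a 1.3-fold higher number from compound 3 to compound 4 (0.11 log units; within the scatter) and so changes the halogen and its ring position together without separating the two compounds. Compound 4 also stays close to the unhalogenated compound 1, with a 1.7-fold higher number from compound 1 to compound 4 (0.22 log units; within the scatter) for that change, whereas chloro in place of methoxy on an aromatic carbon gives a 3.0-fold lower number from compound 2 to compound 4 (0.48 log units; beyond the scatter) and is the first single change shown that clearly moves the number. No measured evidence here explains this difference.

The compounds shown leave open whether the halogen itself or its position matters, as no pair changes only one of these. They also leave open how 5-bromo-1H-indol-2-yl, or a fluoro or methyl group in place of the chloro on compound 4, would behave.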